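The compounds below may be only part of what the source reports. "The series", "measured", "known", "first", "only" and "open" are said of these compounds alone.

Values in a functional assay on MCF7 cells (Homo sapiens) for cytotoxicity, read by MTT assay, with a stated time of 72 h (on this read-out higher numbers stand for weaker inhibition and lower numbers for stronger inhibition), so far
Compound 1 `Cc1cccc(NC(=O)CSC(=S)N[C@H]2CCOC2=O)c1C` gives > 128000 nM which is a limit of the assay and not a number
Compound 2 `O=C(CSC(=S)N[C@H]1CCOC1=O)Nc1cccc(Cl)c1` gives 46600 nM
Compound 3 `O=C(CCl)Nc1ccc(C(=O)/C=C/c2ccc(Cl)cc2)cc1` gives 4100 nM

Compound 3 holds the lowest of the two true numbers, and compound 2 sits clearly higher. Compound 4 `O=C(CCl)Nc1ccc(C(=O)/C=C/c2cccc(Cl)c2)cc1` has the same atoms as compound 3, joined differently, and the whole change is 3-chlorophenyl in place of 4-chlorophenyl on a double-bonded chain carbon bound to a double-bonded chain carbon with nothing else altered. Within the data shown here, no measured pair shows such a move of the chlorine, so the data offer no direct guide to its size. No change beyond the usual scatter is expected, and neither direction is favoured. In this assay the expected result is a 1.2-fold higher number from compound 3 to compound 4 (0.09 log units; within the scatter) and this stays within that scatter. Compound 4 is estimated at 5000 nM with 1500 nM to 14000 nM as its expected range.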

Compound 4, half-maximal inhibitory concentration: 5340 nM
Compound 4: the middle estimate sits 1.1-fold (0.03 log units) below what was measured; the range from low to high includes it.
By their numbers in this assay, from the lowest: compounds 3 and 4 (each within the scatter of the next); then compound 2. At a limit, above all of these: compound 1.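

In this assay the move of the chlorine gives a 1.3-fold higher number from compound 3 to compound 4 (0.11 log units; within the scatter), so the two compounds cannot be told apart. This is the first pair shown that differs in one place, and it shows that, on this core, 3-chlorophenyl and 4-chlorophenyl read alike at this position. Nothing in the data shown explains this result. Still open, from the compounds shown here alone, is how 2-chlorophenyl, or a phenyl carrying an amine or a carboxylic acid in place of the chlorine, would read in this assay.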